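Flipping One Stereocentre in a Substance-P Receptor Antagonist

The source may report more compounds than this note shows. Statements on the series, on what has been measured and on what is new or still open speak of the compounds shown alone.

Of the compounds shown here, two have been measured so far. In an assay on IM-9 cells for displacement of a labelled ligand from Substance-P receptor (Homo sapiens), read by scintillation counting, with a stated time of 30 min (on this read-out lower numbers stand for stronger inhibition and higher numbers for weaker inhibition), compound 1 `CC(=O)N1CCC(C(=O)N2CC[C@H](C(=O)N(C)Cc3cc(C(F)(F)F)cc(C(F)(F)F)c3)[C@@H](c3ccc(C)cc3)C2)CC1` gives 0.18 nM. Compound 2 `Cc1cc(F)ccc1[C@H]1CN(C(=O)C(N)=O)CC[C@@H]1C(=O)N(C)[C@@H](C)c1cc(C(F)(F)F)cc(C(F)(F)F)c1` gives 0.017 nM in this assay, the lowest of the two numbers shown, with compound 1 standing at a higher number, a gap that lies beyond the usual scatter.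

The step examined here leads from compound 2 to compound 3 `Cc1cc(F)ccc1[C@H]1CN(C(=O)C(N)=O)CC[C@@H]1C(=O)N(C)[C@H](C)c1cc(C(F)(F)F)cc(C(F)(F)F)c1`. The change is small on paper: the two compounds have the same atoms and bonds and differ only in configuration as drawn: 1 of 3 stereo elements differ; a stereocentre at a saturated chain carbon is drawn S in compound 2 and R in compound 3. Nothing is added and nothing is removed; only the handedness of one saturated chain carbon is reversed.

Within the data shown here, no measured pair in this set shows what such an inversion does, so any expectation rests on the change alone. Reversing a single stereocentre next to an unchanged framework commonly shifts the number noticeably, and the step from compound 2 to compound 3 is expected to be a 120-fold higher number from compound 2 to compound 3 (2.07 log units; beyond the scatter), toward weaker inhibition. Compound 3 is therefore estimated at 2 nM in this assay, with a plausible range from 0.15 nM to 30 nM.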

Compound 3, half-maximal inhibitory concentration: 0.2 nM
The estimate for compound 3 lay 10-fold (1.00 log units) above the measured number; low and high end bracket the measured number.
By their numbers in this assay, from the lowest: compound 2; then compounds 1 and 3 (each within the scatter of the next).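

Reversing the handedness of this one saturated chain carbon gives a 12-fold higher number from compound 2 to compound 3 (1.07 log units; beyond the scatter) in this assay, so the form drawn S, compound 2, carries the lower number. This is the first pair shown that differs in a single place, and the entire step can be assigned to the arrangement in space at this carbon: the fact that compounds 2 and 3 differ only in the configuration as drawn. The position therefore responds to how its groups are oriented, even when the same atoms and bonds are present.

On these data alone, it remains open whether an ethyl group in place of the methyl group on this carbon would keep the lower number of compound 2, or whether a plain methylene carbon with no methyl group would lose it. As far as these compounds go, the effect of reversing either of the other two stereo elements also remains open.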